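This account rests on a few compounds, and the source may have more. Where it says the series, first, only, none or still open, it means among the compounds named here.

Three analogues share one core. Compound 1 `CCCCNc1nc(N)nc2c1ncn2/C=C1/CC1(CO)CO` carries a butylamino group, compound 2 `CCCSc1nc(N)nc2c1ncn2/C=C1/CC1(CO)CO` a propylsulfanyl group and compound 3 `COCCOc1nc(N)nc2c1ncn2/C=C1/CC1(CO)CO` a 2-methoxyethoxy group. In an ADME assay on CCRF-HSB-2 cells (Homo sapiens) for cytotoxicity, with a stated time of 7 days (on this read-out lower numbers stand for higher toxicity in this test and higher numbers for lower toxicity in this test), compound 2 gives 98000 nM. Compound 1 reaches only an assay limit, > 20000 nM, in this assay. Compound 3 likewise stands at a limit, > 20000 nM, in this assay. The steps a step that the two limits leave unreadable from compound 1 to compound 3 and a step that the limit leaves unreadable from compound 2 to compound 3 therefore have no readable size, and the limit of > 20000 nM in this assay, at which 2 of the 3 values shown sit, shows where most values gather. Compound 4 `CCOc1nc(N)nc2c1ncn2/C=C1/CC1(CO)CO` differs from compound 3 by hydrogen in place of methoxy on a saturated chain carbon, two bonds along the chain from an oxygen on an aromatic ring. Among the compounds with values here, no measured step matches this change, so no shift beyond the scatter is expected, and a further limit is the likeliest outcome. Compound 4 is expected at 40000 nM (range 15000 nM to 150000 nM), a step that the limit leaves unreadable from compound 3 to compound 4.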

Compound 4, half-maximal cytotoxic concentration: > 20000 nM
Compound 4: only a limit was reported; the forecaster's own chance of this, stated with the estimate: 70%; the middle value is on the limit's open side.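

In this assay compound 4 gives > 20000 nM, which is a limit of the assay. None of the steps linking compound 1, compound 2 or compound 3 to compound 4 can be read. On these data alone, whether compound 1, compound 3 and compound 4 differ from one another or from compound 2 stays open.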